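A bulkier side chain on a cyclic peptide scaffold

The source may hold more compounds than are shown below. What is called first, only, known or untested is meant among the compounds shown, and "the series" means these compounds.

Three cyclic peptides have been tested in a functional assay on P388 cells (Mus musculus) for cytotoxicity; on this read-out higher numbers stand for weaker inhibition and lower numbers for stronger inhibition. Compound 1 `COc1ccc(C[C@H]2C(=O)N[C@@H](C)C(=O)N(C)[C@H]3Cc4ccc(cc4)Oc4cc(ccc4OC)C[C@@H](C(=O)N[C@H](C)C(=O)N[C@@H](CCO)C(=O)N2C)N(C)C3=O)cc1` gives 60.3 nM. Compound 2 `C[C@@H]1NC(=O)[C@@H](C)NC(=O)[C@@H]2Cc3ccc(O)c(c3)Oc3ccc(cc3)C[C@@H](C(=O)N2C)N(C)C(=O)[C@H](C)NC(=O)[C@H](Cc2ccccc2)N(C)C1=O` gives 42.7 nM. Compound 3 `CCN1C(=O)[C@@H](C)NC(=O)[C@@H]2Cc3ccc(OC)c(c3)Oc3ccc(cc3)C[C@@H](C(=O)N2C)N(C)C(=O)[C@H](C)NC(=O)[C@H](Cc2ccc(OC)cc2)N(C)C(=O)[C@@H]1C` gives 43.7 nM; its number differs from those of compound 2 and compound 1 by less than the usual scatter, so the three cannot be told apart on potency. Compound 4 `COc1ccc(C[C@H]2C(=O)N[C@@H](C)C(=O)N(C)[C@H]3Cc4ccc(cc4)Oc4cc(ccc4OC)C[C@@H](C(=O)N[C@H](C)C(=O)N(C/C=C/c4ccccc4)[C@@H](C)C(=O)N2C)N(C)C3=O)cc1` has not been measured. It differs from compound 3 in one place: 2-phenylethenyl in place of methyl on a saturated chain carbon bound to an amide-type nitrogen in a ring. Going by the values given here, no measured pair shows the effect of such a change here, so the direction is uncertain; a modest step is expected rather than a large one. The estimate for compound 4 in this assay is 80 nM, between 25 nM and 300 nM, which would be a step of a 1.8-fold higher number from compound 3 to compound 4 (0.26 log units; within the scatter).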

Compound 4, half-maximal inhibitory concentration: 10.7 nM
Beside the measured number, compound 4's estimate is 7.5-fold (0.87 log units) above it; measured number outside the range, below it.
By their numbers in this assay, from the lowest: compound 4; then compounds 2, 3 and 1 (each within the scatter of the next).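

On the saturated chain carbon bound to an amide-type nitrogen in a ring, replacing methyl with the much larger 2-phenylethenyl gives a 4.1-fold lower number from compound 3 to compound 4 (0.61 log units; beyond the scatter), which here means stronger inhibition. Going by these compounds alone, the earlier compounds offered no pair that isolated a change at this place, so this is the first sign that a group of eight carbons with an aromatic ring is compatible with activity here. The compounds shown leave open whether the double bond, the aromatic ring or the added length goes with the step. A saturated 2-phenylethyl group or a plain propyl chain in the same place would help separate these. No available evidence explains the lower number.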